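Chloro for Ethyl on the Sulfonamide Aryl Ring

The source may report more compounds than this note shows. Statements on the series, on what has been measured and on what is new or still open speak of the compounds shown alone.

Compound 1 `CCc1ccc(NS(=O)(=O)c2ccc(N3CCNC3=O)cc2)cc1` gives 810 nM.
Compound 2 `O=C1NCCN1c1ccc(S(=O)(=O)Nc2ccc(OC(F)F)cc2)cc1` gives 760 nM.
Compound 3 `O=C1NCCN1c1ccc(S(=O)(=O)Nc2ccc(C3CCCCC3)cc2)cc1` gives > 1000 nM.

Of the compounds shown here, three sharing one core have been tested in a functional assay on MCF7 cells (Homo sapiens) for antiproliferative activity, read by sulforhodamine B assay, with a stated time of 48 h; a higher number here means a weaker inhibitor, a lower number a stronger inhibitor. Compound 1 stands highest of the two plain numbers, with compound 2 nearest, and the step of a 1.1-fold lower number from compound 1 to compound 2 (0.03 log units; within the scatter) lies within the scatter. Compound 3 returns only a limit in this assay rather than a number. That reading sits at the limit of > 1000 nM in this assay, at which 1 of the 3 values shown sits, so the steps of an at least 1.2-fold higher number from compound 1 to compound 3 (0.09 log units; that floor lies within the scatter) and an at least 1.3-fold higher number from compound 2 to compound 3 (0.11 log units; that floor lies within the scatter) have floors only, and those floors lie within the scatter.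

Compound 4 `O=C1NCCN1c1ccc(S(=O)(=O)Nc2ccc(Cl)cc2)cc1` has not yet been measured. It differs from compound 1 by chloro in place of ethyl on an aromatic carbon. For the measured compounds named here, the steps that bear on this change are those at the same aromatic carbon: a 1.1-fold lower number from compound 1 to compound 2 (0.03 log units; within the scatter) and an at least 1.2-fold higher number from compound 1 to compound 3 (0.09 log units; that floor lies within the scatter), neither of which moves beyond the scatter. On that basis no step beyond the scatter is expected in this assay for compound 4 in either direction, and the step the estimate implies is a 1.0-fold lower number from compound 1 to compound 4 (0.01 log units; within the scatter). Compound 4 is therefore estimated at 800 nM, with an expected range from 400 nM to 1600 nM.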

Compound 4, half-maximal inhibitory concentration: 170 nM
The estimate for compound 4 lay 4.7-fold (0.67 log units) above the measured number; measured number below the stated range.
By their numbers in this assay, from the lowest: compound 4; then compounds 2 and 1 (each within the scatter of the next). At a limit, above all of these: compound 3.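

In this assay, this position proved able to move the number beyond the scatter, something the ethyl, difluoromethoxy and cyclohexyl compounds had not shown among themselves: chloro gives a 4.8-fold lower number from compound 1 to compound 4 (0.68 log units; beyond the scatter) and a 4.5-fold lower number from compound 2 to compound 4 (0.65 log units; beyond the scatter). Compounds 1 and 2 lie within the scatter of each other, so the replacement of either group by chloro reads as much the same change, and the difference between ethyl and difluoromethoxy counts for little beside it. Against compound 3 the result is an at least 5.8-fold lower number from compound 3 to compound 4 (0.76 log units; beyond the scatter), which is only a floor, since compound 3 returns a limit and not a number: the limit of > 1000 nM in this assay, at which 1 of the 4 values shown sits.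

With a single chloro compound among the four, the compounds shown cannot say whether this drop in the number belongs to chloro alone or would also appear with fluoro, bromo or a small group such as methyl. They also leave open how an amine or a carboxylic acid on this aromatic carbon would read, and why chloro differs from the other three groups here.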